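Dichloroacetanilides on KB Cells: Iodo Gives Way to Trifluoromethylsulfanyl

The source may hold more compounds than are shown below. What is called first, only, known or untested is meant among the compounds shown, and "the series" means these compounds.

Compound 1 `O=C(Nc1ccccc1[N+](=O)[O-])C(Cl)Cl` and compound 2 `O=C(Nc1cccc(I)c1)C(Cl)Cl` share one core and were both tested in a functional assay on KB cells (Homo sapiens) for antiproliferative activity, read by MTT assay, with a stated time of 72 h; a higher number here means a weaker inhibitor, a lower number a stronger inhibitor. Compound 1 gives 253000 nM, whereas compound 2 gives 5250 nM, the lower of the two numbers and well apart from compound 1. Compound 3 `O=C(Nc1cccc(SC(F)(F)F)c1)C(Cl)Cl` has not yet been measured in this assay. It differs from compound 2 in one place: (trifluoromethyl)sulfanyl in place of iodo on an aromatic carbon. Going by the values given here, no measured pair covers this change, so the expectation rests on compound 2 alone. The step of a 1.1-fold lower number from compound 2 to compound 3 (0.02 log units; within the scatter) is expected to stay within the usual scatter, in no firm direction. Compound 3 is therefore estimated at 5000 nM, within the range 1500 nM to 16000 nM.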

Compound 3, half-maximal inhibitory concentration: 4840 nM
For compound 3 the middle estimate is 1.0-fold (0.01 log units) above the measured one; measured number inside the range.
By their numbers in this assay, from the lowest: compounds 3 and 2 (each within the scatter of the next); then compound 1.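

In this assay, putting (trifluoromethyl)sulfanyl in place of iodo on this aromatic carbon gives a 1.1-fold lower number from compound 2 to compound 3 (0.04 log units; within the scatter) even though a single iodine gives way to a group of 5 heavy atoms. Going by these compounds alone, this is the first step read at this position, and it shows that the two groups cannot be told apart here. Going by these compounds, whether an amine or a carboxylic acid on the same carbon would keep the number in this range remains open, as does whether the exchange holds elsewhere on the ring. No measured evidence bears on this result.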